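Shortening the ether chain of a benzotriazine dioxide series

This account rests on a few compounds, and the source may have more. Where it says the series, first, only, none or still open, it means among the compounds named here.

Compound 1 `CCCCOCNc1n[n+]([O-])c2ccccc2[n+]1[O-]` gives 14700 nM in a functional assay on PC-3 cells (Homo sapiens) for cytotoxicity, read by MTT assay, with a stated time of 72 h; a lower number here means a stronger inhibitor, a higher number a weaker inhibitor.
Compound 2 `CC(C)CCOCNc1n[n+]([O-])c2ccccc2[n+]1[O-]` gives 11100 nM in this assay.
Compound 3 `CCCCCCCOCNc1n[n+]([O-])c2ccccc2[n+]1[O-]` gives 1210 nM in this assay.

Compound 3 holds the lowest number of the three; the nearest is compound 2, and the furthest compound 1, both beyond the scatter. Compound 4 `CCCCCOCNc1n[n+]([O-])c2ccccc2[n+]1[O-]` differs from compound 3 by hydrogen in place of ethyl on a saturated chain carbon, five bonds along the chain from an oxygen on a saturated carbon. Going by the values given here, the steps that bear on this are the chain extensions a 12-fold lower number from compound 1 to compound 3 (1.08 log units; beyond the scatter) and a 9.2-fold lower number from compound 2 to compound 3 (0.96 log units; beyond the scatter), each of which lowered the number beyond the scatter. Cutting the chain back is therefore expected to raise the number, though by less than the full extension, since compound 4 keeps a chain longer than that of compound 1. The estimate for compound 4 in this assay is 4500 nM, in the range 1500 nM to 12000 nM, a step of a 3.7-fold higher number from compound 3 to compound 4 (0.57 log units; beyond the scatter).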

Compound 4, half-maximal inhibitory concentration: 9200 nM
The estimate for compound 4 lay 2.0-fold (0.31 log units) below the measured number; measured number inside the range.
By their numbers in this assay, from the lowest: compound 3; then compounds 4, 2 and 1 (each within the scatter of the next).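

In this assay, taking away ethyl at this place, five bonds along the chain from an oxygen on a saturated carbon, removes most of what the longest chain had gained (a 7.6-fold higher number from compound 3 to compound 4 (0.88 log units; beyond the scatter)). The gain is not spread evenly along the chain: methyl in place of hydrogen four bonds along from that oxygen stays within the scatter (a 1.6-fold lower number from compound 1 to compound 4 (0.20 log units; within the scatter)), as does the change from the branched chain (a 1.2-fold lower number from compound 2 to compound 4 (0.08 log units; within the scatter)), so among these compounds the large step appears only with the final ethyl. No measurement offers an explanation for this sharp step. As far as these compounds go, whether a still longer chain lowers the number further, or whether a chain ending in an amine would keep the step, remains open.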